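The source may report more compounds than this note shows. Statements on the series, on what has been measured and on what is new or still open speak of the compounds shown alone.

Measured compounds:
compound 1, `COc1cc2c(Oc3ccc(NC(=O)c4nn(-c5ccccc5OC(F)(F)F)c(=O)cc4C)cc3F)ccnc2cc1OCCCN1CCCC1`, 60 nM
compound 2, `COc1cc2c(Oc3ccc(NC(=O)c4nn(-c5ccccc5OC(F)(F)F)c(=O)cc4C)cc3F)ccnc2cc1OCCCN1CCCCC1`, 40 nM
compound 3, `COc1cc2c(Oc3ccc(NC(=O)c4nn(-c5cccc(F)c5)c(=O)cc4C)cc3F)ccnc2cc1OCCCN1CCCC1`, 120 nM

The three compounds were tested in a functional assay on MKN-45 cells (Homo sapiens) for inhibition, read by MTT assay, with a stated time of 72 h; on this read-out higher numbers stand for weaker inhibition and lower numbers for stronger inhibition. Compound 1 and compound 2 share a core and differ in one place: piperidin-1-yl in place of pyrrolidin-1-yl on a saturated chain carbon, three bonds along the chain from an oxygen on an aromatic ring. That change gave a 1.5-fold lower number from compound 1 to compound 2 (0.18 log units; within the scatter). Compound 3 differs from compound 1 in another place: 3-fluorophenyl in place of 2-(trifluoromethoxy)phenyl on an aromatic nitrogen. The core change gave a 2.0-fold higher number from compound 1 to compound 3 (0.30 log units; within the scatter). Among the compounds with values here, compound 3 and compound 2 are the only pair whose values lie beyond the scatter of one another, and no step is counted between them, so only their two values speak.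

Compound 4, `COc1cc2c(Oc3ccc(NC(=O)c4nn(-c5cccc(F)c5)c(=O)cc4C)cc3F)ccnc2cc1OCCCN1CCCCC1`, has not been measured in this assay. It differs from compound 3 exactly as compound 2 differs from compound 1: piperidin-1-yl in place of pyrrolidin-1-yl on a saturated chain carbon, three bonds along the chain from an oxygen on an aromatic ring. The place of the change is the same in both pairs, so it is the same change made on the core of compound 3 rather than the core of compound 1. Within the data shown here, the only guide to what it will do is the single earlier instance, where the step of a 1.5-fold lower number from compound 1 to compound 2 (0.18 log units; within the scatter) stayed within the scatter. Compound 4 is therefore expected to show a step of about the same small size, a 1.5-fold lower number from compound 3 to compound 4 (0.18 log units; within the scatter), because compound 3 starts from 120 nM and the earlier step was a 1.5-fold lower number from compound 1 to compound 2 (0.18 log units; within the scatter). For compound 4 the estimated value in this assay is 80 nM, with a likely range from 40 nM to 160 nM, since a single earlier step gives little certainty.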

Compound 4, half-maximal inhibitory concentration: 130 nM
Compound 4: middle estimate off by 1.6-fold (0.21 log units), on the low side; measured number inside the range.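

In this assay, piperidin-1-yl in place of pyrrolidin-1-yl gave a 1.1-fold higher number from compound 3 to compound 4 (0.03 log units; within the scatter), and this step cannot be told apart from its earlier instance: the same change on two cores in this assay, a 1.5-fold lower number (0.18 log units; within the scatter) from compound 1 to compound 2 and a 1.1-fold higher number (0.03 log units; within the scatter) from compound 3 to compound 4, 1.6-fold (0.21 log units) apart, within the scatter of two such steps

The exchange of 2-(trifluoromethoxy)phenyl for 3-fluorophenyl on the aromatic nitrogen, read with piperidin-1-yl on the chain, gave a 3.3-fold higher number from compound 2 to compound 4 (0.51 log units; beyond the scatter), and it too agrees with its earlier instance: the same change on two cores in this assay, a 2.0-fold higher number (0.30 log units; within the scatter) from compound 1 to compound 3 and a 3.3-fold higher number (0.51 log units; beyond the scatter) from compound 2 to compound 4, 1.6-fold (0.21 log units) apart, within the scatter of two such steps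

Within the data shown here, both changes therefore carried from one core to the other with no difference that these data can resolve, but the evidence is only two pairs of steps in a single cell assay, so it does not show that either change would behave the same way on any other core, nor that the two steps are truly equal rather than merely too close to separate.

From the compounds shown here alone, it remains open how a different amine at the end of the chain, such as morpholin-4-yl or 4-methylpiperazin-1-yl, or a shorter or longer chain would fare. Also open is how other groups on the aromatic nitrogen, such as an unsubstituted phenyl or a pyridyl, would compare with the two aryl groups shown here.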